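The compounds below may be only part of what the source reports. "The series", "measured", "known", "first", "only" and "open" are said of these compounds alone.

For the measured compounds named here, in a functional assay with Rattus norvegicus as the target (a higher number here means that more compound is needed for the effect, a lower number that less compound is needed), compound 2 `CN(C)S(=O)(=O)c1ccc2c(c1)C(n1ccccc1=O)=CC(C)(C)O2` gives 95.5 nM, the lowest of the two numbers measured so far; its nearest neighbour is compound 1 `CC1(C)C=C(n2ccccc2=O)c2cc(S(=O)(=O)Nc3ccc([N+](=O)[O-])cc3)ccc2O1`, which gives 10200 nM. Going by the values given here, the only measured step is a 110-fold lower number from compound 1 to compound 2 (2.03 log units; beyond the scatter), in which dimethylamino took the place of (4-nitrophenyl)amino on the sulfonyl sulfur. Compound 3 `CC1(C)C=C(n2ccccc2=O)c2cc(S(=O)(=O)NC(=O)Nc3ccccc3)ccc2O1` differs from compound 2 by (phenylcarbamoyl)amino in place of dimethylamino on a sulfonyl sulfur. This change brings an amino group with hydrogen-bond donors back onto the sulfonyl sulfur, as compound 1 had, so the measured step bears on it in reverse, although the entering (phenylcarbamoyl)amino is not the same group that left compound 1. Among the compounds with values here, compound 3 is therefore expected to give a higher number than compound 2, with an estimated step of a 21-fold higher number from compound 2 to compound 3 (1.32 log units; beyond the scatter), expected to be smaller than the measured step because the entering group is not the one that left compound 1 in a 110-fold lower number from compound 1 to compound 2 (2.03 log units; beyond the scatter). The expected value for compound 3 is 2000 nM, in a range from 300 nM to 15000 nM.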

Compound 3, half-maximal effective concentration: 10000 nM
For compound 3 the middle estimate is 5.0-fold (0.70 log units) below the measured one; low and high end bracket the measured number.
By their numbers in this assay, from the lowest: compound 2; then compounds 3 and 1 (each within the scatter of the next).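

In this assay, placing (phenylcarbamoyl)amino on the sulfonyl sulfur gives a 100-fold higher number from compound 2 to compound 3 (2.02 log units; beyond the scatter), so compound 2 with its dimethylamino now has a lower number than two compounds carrying different groups at this place, not just one. Exchanging the group on the sulfonamide nitrogen gives a 1.0-fold lower number from compound 1 to compound 3 (0.01 log units; within the scatter), which means that phenylcarbamoyl and 4-nitrophenyl cannot be told apart here, even though the two groups differ. No experimental evidence is available to explain either step.

Compounds 1 and 3 both keep a hydrogen on the sulfonamide nitrogen and both carry a larger group than dimethylamino, so the compounds shown cannot separate these two differences. A plain amino group or a methylamino group on the sulfonyl sulfur would help to pull them apart.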